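The compounds below may be only part of what the source reports. "The series", "measured", "known", "first", "only" and "open" are said of these compounds alone.

In an ADME assay on BJ cells (Homo sapiens) for cytotoxicity, read by MTT assay, with a stated time of 72 h (a lower number here means a stronger inhibitor, a higher number a weaker inhibitor), compound 3 `COc1cccc(CNc2ncnc3c2ncn3C2CCCCO2)c1` stands at a limit of the assay, giving > 100000 nM. The same limit is recorded for compound 1 `Oc1cccc(CNc2ncnc3c2ncn3C2CCCCO2)c1`, which gives > 100000 nM. Compound 2 `COc1ccccc1CNc1ncnc2c1ncn2C1CCCCO1` likewise reaches only a limit, with > 100000 nM. Going by the values given here, because all three values sit at the limit of > 100000 nM in this assay, at which 3 of the 3 values shown sit, none of the measured steps can be read: a step that the two limits leave unreadable from compound 1 to compound 3, a step that the two limits leave unreadable from compound 1 to compound 2 and a step that the two limits leave unreadable from compound 2 to compound 3 are each of unknown size. Compound 4 `Oc1cccc(CNc2ncnc3c2ncn3C2CCCCO2)c1O` is not yet measured and differs from compound 3 by 2,3-dihydroxyphenyl in place of 3-methoxyphenyl on a saturated chain carbon bound to a nitrogen on an aromatic ring. Among the compounds with values here, the step from compound 1 to compound 3 touched the same oxygen on an aromatic ring, a methyl in place of hydrogen, but it was unreadable, so no measured step bears readably on the present change. With every neighbour at the limit, no step beyond the scatter can be expected in this assay. Compound 4 is therefore estimated at 150000 nM, between 80000 nM and 400000 nM, most likely reported again only as a limit. The expected step that the limit leaves unreadable from compound 3 to compound 4 is essentially none.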

Compound 4, half-maximal inhibitory concentration: 63300 nM
Estimate against measurement, compound 4: 2.4-fold (0.37 log units) above; the whole stated range lies above it.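

In this assay, compound 4 alone among the four compounds shown gives a number in place of a limit: the limit of > 100000 nM in this assay, at which 3 of the 4 values shown sit.

Placing 2,3-dihydroxyphenyl on the saturated chain carbon bound to a nitrogen on an aromatic ring gives an at least 1.5-fold lower number from compound 3 to compound 4 (0.19 log units; that floor lies within the scatter) and an at least 1.5-fold lower number from compound 2 to compound 4 (0.19 log units; that floor lies within the scatter), while hydroxy in place of hydrogen on an aromatic carbon gives an at least 1.5-fold lower number from compound 1 to compound 4 (0.19 log units; that floor lies within the scatter). Each of these steps is only a floor within the scatter, so the result shows that this change can bring a readable number at this position, but not that it lowers the number by any established amount.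

From the compounds shown here alone, the true size of all three steps remains open. Also open, going by these compounds, is whether a phenyl ring carrying an amine in place of the hydroxy groups would give a readable number in this assay.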